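The source may report more compounds than this note shows. Statements on the series, on what has been measured and on what is new or still open speak of the compounds shown alone.

Measured so far in an in vitro ADME assay on microsomes from liver (Mus musculus) for metabolic stability, read by LC-MS; on this read-out higher numbers stand for a longer-lived compound and lower numbers for a shorter-lived compound:
- Compound 1 `CC(C)N1C(=O)C(=O)N=C1/N=C(\NOCc1ccccc1)Nc1ccc(Cl)c(Cl)c1`: > 1 h (a limit of the assay)
- Compound 2 `CC(C)N1C(=O)C(=O)N=C1/N=C(\NCC(C)(C)C)Nc1ccc(Cl)c(Cl)c1`: > 1 h (a limit of the assay)
- Compound 3 `CCCCCCN/C(=N\C1=NC(=O)C(=O)N1C(C)C)Nc1ccc(Cl)c(Cl)c1`: 0.579 h

Among the measured compounds shown here, compound 3 stands at 0.579 h, the only true number so far. The other two values are limits.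

Compound 4 `CC(C)N1C(=O)C(=O)N=C1/N=C(\NCCCCN1CCCC1)Nc1ccc(Cl)c(Cl)c1` is reached from compound 3 by one change at the chain end: pyrrolidin-1-yl in place of ethyl on a saturated chain carbon, four bonds along the chain from an amine nitrogen. In words, this is pyrrolidin-1-yl in place of ethyl on a saturated chain carbon, four bonds along the chain from an amine nitrogen.

For the measured compounds named here, no measured step makes this change, so the evidence is indirect. The closest steps are an at least 1.7-fold lower number from compound 1 to compound 3 (0.23 log units; that floor lies within the scatter) and an at least 1.7-fold lower number from compound 2 to compound 3 (0.23 log units; that floor lies within the scatter). Both alter the group on the amine nitrogen, and neither has a floor that clears the scatter. The remaining step, a step that the two limits leave unreadable from compound 1 to compound 2, adds no size.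

With so little to go on, the expectation stays anchored on compound 3 at 0.579 h. In this assay the expected result is a 1.2-fold lower number from compound 3 to compound 4 (0.06 log units; within the scatter), with no step beyond the scatter in either direction. For compound 4 the estimated half-life is 0.5 h, with an expected range of 0.2 h to 1 h.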

Compound 4, half-life: > 1 h
Compound 4: no number, only a limit (the forecaster's own chance of this, stated with the estimate: 15%); at least 2.0-fold (0.30 log units) between middle value and limit.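

In this assay, among the compounds shown here, the one hexyl compound with a true number does not set a ceiling for this chain position: with pyrrolidin-1-yl in place of ethyl, four bonds along the chain from an amine nitrogen, the read-out gives an at least 1.7-fold higher number from compound 3 to compound 4 (0.23 log units; that floor lies within the scatter). Compound 4 gives > 1 h, which is a limit of the assay. So a chain end carrying a five-membered non-aromatic ring with a nitrogen is compatible with this limit, as are the neopentyl group of compound 2 and the benzyloxy group of compound 1, but the steps among these three compounds cannot be read, and no order among them can be drawn: the limit of > 1 h in this assay, at which 3 of the 4 values shown sit.

From the compounds shown here alone, how far compound 4 lies past its limit remains open, and with it the true size of the step from the hexyl compound, whose floor alone does not clear the scatter. Also open, going by these compounds, is whether the ring or the nitrogen goes with the step, which a cyclopentyl group or an open-chain dimethylamino group at the same chain end would help to separate.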